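Fluoro for hydrogen on the thiourea aryl ring

The source may report more compounds than this note shows. Statements on the series, on what has been measured and on what is new or still open speak of the compounds shown alone.

Compounds measured:
- compound 1, `NC(=O)c1c(NC(=O)c2ccccc2Cl)sc2c1CCN(Cc1ccccc1Cl)C2`: 4430 nM
- compound 2, `NC(=O)c1c(NC(=O)c2ccccc2Cl)sc2c1CCN(Cc1c(Cl)cccc1Cl)C2`: 4740 nM
- compound 3, `NC(=O)c1c(NC(=O)c2ccccc2Cl)sc2c1CCN(C(=S)Nc1ccccc1)C2`: 15600 nM

In a functional assay on MKN-74 cells (Homo sapiens) for antiproliferative activity, with a stated time of 24 h (a lower number here means a stronger inhibitor, a higher number a weaker inhibitor), compound 3 gives the highest of the three numbers; the step of a 3.5-fold higher number from compound 1 to compound 3 (0.55 log units; beyond the scatter) and the step of a 3.3-fold higher number from compound 2 to compound 3 (0.52 log units; beyond the scatter) both lie beyond the scatter, so compound 3 is the weakest inhibitor of the measured set.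

Compound 4, `NC(=O)c1c(NC(=O)c2ccccc2Cl)sc2c1CCN(C(=S)Nc1ccccc1F)C2`, differs from compound 3 by one change: fluoro in place of hydrogen on an aromatic carbon.

The closest measured comparison is the step of a 1.1-fold higher number from compound 1 to compound 2 (0.03 log units; within the scatter), where a halogen was likewise added to an aromatic carbon of the ring carried on the amine nitrogen of the shared core, and the number did not move beyond the scatter. That precedent concerns a chloro substituent on a benzyl group rather than a fluoro substituent on an anilino group, so it is only a partial guide. Nothing in the measured set points to a shift in either direction.

On that basis compound 4 is expected to stay close to compound 3, with an estimated step of a 1.1-fold lower number from compound 3 to compound 4 (0.05 log units; within the scatter) in this assay, well inside the scatter. The estimate for compound 4 in this assay is 14000 nM, within a range from 6000 nM to 35000 nM.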

Compound 4, half-maximal inhibitory concentration: 12600 nM
Beside the measured number, compound 4's estimate is 1.1-fold (0.05 log units) above it, and the stated range covers the measured number.
By their numbers in this assay, from the lowest: compounds 1 and 2 (each within the scatter of the next); then compounds 4 and 3 (each within the scatter of the next).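

In this assay, for the compounds shown here, going from phenyl to 2-fluorophenyl on the thiourea gives a 1.2-fold lower number from compound 3 to compound 4 (0.09 log units; within the scatter) and so is the first reading of a substituent on this aryl ring: fluoro in place of hydrogen, ortho to a large group, leaves the number inside the scatter. The gap between the thioureas and the chlorobenzyl compounds remains after this change, with a 2.8-fold higher number from compound 1 to compound 4 (0.45 log units; beyond the scatter) and a 2.7-fold higher number from compound 2 to compound 4 (0.42 log units; beyond the scatter) both modest but beyond the scatter, just as compound 3 stood apart from compound 1 and compound 2. No measurement accompanies these numbers that could explain either the flat fluoro step or the remaining gap.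

A single fluoro at one place leaves open whether a larger group on this ring, such as methoxy, trifluoromethyl or a carboxylic acid, or a group elsewhere on the same ring, would move the number beyond the scatter. From the compounds shown here alone, it also remains open whether a urea, with oxygen in place of the thiourea sulfur, would narrow the gap to the chlorobenzyl compounds.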